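The compounds below may be only part of what the source reports. "The series", "measured", "known", "first", "only" and "open" are said of these compounds alone.

Measured so far: compound 1 `OC(CCn1nc2c(Br)c(Br)c(Br)c(Br)c2n1)c1cccc(Br)c1` with 123%, compound 2 `OC(CCn1nc2c(Br)c(Br)c(Br)c(Br)c2n1)c1ccc(F)cc1` with 104% and compound 3 `CC(O)CCn1nc2c(Br)c(Br)c(Br)c(Br)c2n1` with 113%, all in a functional assay on CCRF-CEM cells (Homo sapiens) for antiproliferative activity, read by MTT assay, with a stated time of 24 h, tested at 25 uM; on this read-out higher numbers stand for a weaker effect at the one concentration tested and lower numbers for a stronger effect.

Compound 3 stands second highest of the three; its nearest neighbour is compound 2 and its furthest is compound 1, both within the scatter. Compound 4 `OC(CCn1nc2c(Br)c(Br)c(Br)c(Br)c2n1)c1ccc(Cl)cc1` differs from compound 3 by 4-chlorophenyl in place of methyl on a saturated chain carbon bound to an oxygen on a saturated carbon and a saturated chain carbon. Among the measured compounds shown here, two steps bear on this: a number 10 percentage points lower from compound 1 to compound 3 (within the scatter) and a number 9 percentage points higher from compound 2 to compound 3 (within the scatter), neither beyond the scatter. A 4-halophenyl entering for methyl is the reverse of the second of these, so the expected step of a number 8 percentage points lower from compound 3 to compound 4 (within the scatter) is small and within the scatter, if anything slightly downward. Compound 4 is therefore estimated at 105%, between 90% and 122%.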

Compound 4, a percentage reported as activity, at one concentration (the size of the read-out at that concentration, not a potency): 106%
The estimate for compound 4 lay 1 percentage points below the measured number, and the stated range covers the measured number.
By their numbers in this assay, from the lowest: compounds 2, 4, 3 and 1 (each within the scatter of the next, the first and the last beyond it).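

In this assay, chloro in place of fluoro on an aromatic carbon makes no difference beyond the scatter (a number 2 percentage points higher from compound 2 to compound 4 (within the scatter)), and neither does 4-chlorophenyl in place of methyl (a number 7 percentage points lower from compound 3 to compound 4 (within the scatter)). Among the compounds shown here, the only step here beyond the scatter is modest and comes with 4-chlorophenyl in place of 3-bromophenyl (a number 17 percentage points lower from compound 1 to compound 4 (beyond the scatter)), matching the modest step already seen with 4-fluorophenyl. Nothing available explains these steps.

From the compounds shown here alone, whether 4-bromophenyl at this carbon would read with compound 1 or with compound 4 remains open. So does the effect of an amine or a longer chain there.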